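Swapping Fluoro for Chloro on a Shared Core

The source may report more compounds than this note shows. Statements on the series, on what has been measured and on what is new or still open speak of the compounds shown alone.

Two measured compounds share one core and differ only in the halogen on an aromatic carbon. Compound 1 `CN1CCCN(CCn2ccc3ccc(Br)cc32)CC1` carries a bromo group, and in an assay on HEK293 cells for binding affinity to 5-hydroxytryptamine receptor 7 (Homo sapiens), read by radioligand binding (on this read-out lower numbers stand for stronger inhibition and higher numbers for weaker inhibition), compound 1 gives 31 nM. Compound 2 `CN1CCCN(CCn2ccc3ccc(F)cc32)CC1` carries a fluoro group in the same place, and in this assay compound 2 gives 288 nM. Going by the values given here, the one measured step shows a 9.3-fold higher number from compound 1 to compound 2 (0.97 log units; beyond the scatter). Of these two numbers, compound 2 stands highest, so it is the weaker binder of the pair.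

Compound 3 `CN1CCCN(CCn2ccc3ccc(Cl)cc32)CC1` is not yet measured. It differs from compound 2 by chloro in place of fluoro on an aromatic carbon. Among the compounds with values here, the only step that bears on this change is a 9.3-fold higher number from compound 1 to compound 2 (0.97 log units; beyond the scatter), where exchanging one halogen for another at this spot moved the number well beyond the scatter. Because a 9.3-fold higher number from compound 1 to compound 2 (0.97 log units; beyond the scatter) ran toward a weaker number when fluoro came in, the expected step for the reverse direction of halogen exchange is a 4.1-fold lower number from compound 2 to compound 3 (0.61 log units; beyond the scatter), toward a lower number. For compound 3 the estimate in this assay is 70 nM, with a range from 30 nM to 200 nM.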

Compound 3, inhibition constant: 34 nM
For compound 3 the middle estimate is 2.1-fold (0.31 log units) above the measured one; the measured number falls inside the stated range.
By their numbers in this assay, from the lowest: compounds 1 and 3 (each within the scatter of the next); then compound 2.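

Putting chloro in place of fluoro gives an 8.5-fold lower number from compound 2 to compound 3 (0.93 log units; beyond the scatter), a shift of about the same size as the one seen when fluoro replaced bromo, a 9.3-fold higher number from compound 1 to compound 2 (0.97 log units; beyond the scatter). The other new comparison, a 1.1-fold higher number from compound 1 to compound 3 (0.04 log units; within the scatter), shows that chloro and bromo cannot be told apart at this position in this assay, so among these three halogens, fluoro alone stands apart, with the higher number and steps beyond the scatter to both other compounds. Nothing here explains why fluoro separates from chloro and bromo, so the result remains a description of the numbers and offers no account of their origin.

Three halogens at a single position cannot show whether iodo, or a non-halogen group such as methoxy or nitrile, would fall with chloro and bromo or with fluoro. From the compounds shown here alone, it also remains open whether the same separation would hold with a halogen elsewhere on the six-membered aromatic ring, or with a longer chain in the rest of the shared core.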